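Replacing the Nitrile End of the Alkenyl Arm

This account rests on a few compounds, and the source may have more. Where it says the series, first, only, none or still open, it means among the compounds named here.

Compound 1 `O=Cc1ccc(-c2cnc(C(=O)CCCCCCc3ccccc3)o2)nc1` and compound 2 `N#C/C=C/c1ccc(-c2cnc(C(=O)CCCCCCc3ccccc3)o2)nc1` share one core and differ only in the group attached to an aromatic carbon. In an assay for inhibition of Fatty-acid amide hydrolase 1 (Rattus norvegicus), using a Dixon plot, with a stated time of 3 h (a lower number here means a stronger inhibitor, a higher number a weaker inhibitor), compound 1 gives 2 nM, and compound 2 gives 2.7 nM. The step of a 1.4-fold higher number from compound 1 to compound 2 (0.13 log units; within the scatter) shows that exchanging formyl for 2-cyanoethenyl left the number within the scatter, so compound 2 holds the higher of the two numbers without being separable from compound 1. Compound 3 `C[S+]([O-])/C=C/c1ccc(-c2cnc(C(=O)CCCCCCc3ccccc3)o2)nc1` keeps the double-bonded chain but changes its end: a group of 3 heavy atoms (1 carbon, 1 oxygen, 1 sulfur; no ring) in place of a group of 2 heavy atoms (1 carbon, 1 nitrogen; no ring), on a double-bonded chain carbon bound to a double-bonded chain carbon. Among the measured compounds shown here, no measured step touches this end of the chain; the only step available, from formyl to 2-cyanoethenyl, lay within the scatter and bears on the new change only in showing that this position accepted a different group. Compound 3 is therefore expected to shift by no more than a 1.5-fold higher number from compound 2 to compound 3 (0.17 log units; within the scatter) in this assay. The value estimated for compound 3 is 4 nM, with an expected range from 1.5 nM to 12 nM.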

Compound 3, inhibition constant: 1 nM
Beside the measured number, compound 3's estimate is 4.0-fold (0.60 log units) above it; measured number outside the range, below it.
By their numbers in this assay, from the lowest: compounds 3, 1 and 2 (each within the scatter of the next, the first and the last beyond it).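

Among the compounds shown here, at the end of the double-bonded chain, the earlier compounds showed nothing, since their only step exchanged a whole group on an aromatic carbon; in this assay, the group of 3 heavy atoms (1 carbon, 1 oxygen, 1 sulfur) in place of cyano gives a 2.7-fold lower number from compound 2 to compound 3 (0.43 log units; beyond the scatter), the first step here to lie beyond the scatter. The whole arm in place of formyl gives a 2.0-fold lower number from compound 1 to compound 3 (0.30 log units; within the scatter), so this arm cannot be separated from formyl on an aromatic carbon. Nothing given here accounts for the difference between the two chain ends.

The compounds shown leave open how an amine, a carboxylic acid or a methyl ester would fare at this chain end. They also leave open whether the same end keeps its number on a saturated two-carbon chain.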